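Trimming the oxan-4-yl ether of compound 1 to a hydroxy

This account rests on a few compounds, and the source may have more. Where it says the series, first, only, none or still open, it means among the compounds named here.

Compound 1 `CC(C)(C)C#Cc1cc(N(C(=O)[C@H]2CC[C@H](C)CC2)[C@H]2CC[C@H](OC3CCOCC3)CC2)c(C(=O)O)s1` carries an (oxan-4-yl)oxy substituent on its saturated ring and is examined in an ADME assay on MT4 cells (Homo sapiens) for cytotoxicity, with a stated time of 5 days; a higher number here means that more compound is tolerated, a lower number that less compound is tolerated. In this assay compound 1 gives > 20000 nM, which is a limit of the assay rather than a number. Compound 2 `CC(C)N(c1cc(C#CC(C)(C)C)sc1C(=O)O)C(=O)[C@H]1CC[C@H](CF)CC1` likewise gives > 20000 nM, again a limit. Compound 3 `CC(C)N(C(=O)[C@@H]1CC[C@@H]2C[C@@H]2CC1)c1cc(C#CC(C)(C)C)sc1C(=O)O` gives > 20000 nM, also a limit. The step from compound 2 to compound 3, a step that the two limits leave unreadable from compound 2 to compound 3, swaps one acyl group for another and therefore tells nothing about size. The whole picture so far is summed up by the limit of > 20000 nM in this assay, at which 3 of the 3 values shown sit.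

Compound 4 `CC(C)(C)C#Cc1cc(N(C(=O)[C@H]2CC[C@H](C)CC2)[C@H]2CC[C@H](O)CC2)c(C(=O)O)s1` differs from compound 1 by hydrogen in place of oxan-4-yl on an oxygen on a saturated carbon. Among the measured compounds shown here, no measured step touches this position, and because every value shown sits at the limit of > 20000 nM in this assay, at which 3 of the 3 values shown sit, no size can be read for any change at all. The step implied for the estimate, a step that the limit leaves unreadable from compound 1 to compound 4, is expected to amount to nothing beyond the scatter. Compound 4 is expected to give about 30000 nM, between 12000 nM and 100000 nM, most likely reported once more as a limit.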

Compound 4, half-maximal cytotoxic concentration: > 20000 nM
Compound 4: only a limit was reported; the forecaster's own chance of this, stated with the estimate: 85%; the middle value lies beyond the limit too.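

In this assay compound 4 gives > 20000 nM, which is a limit and not a number. No size can be read for the change from compound 1 to compound 4, since both stand at that limit: the limit of > 20000 nM in this assay, at which 4 of the 4 values shown sit.

The compounds shown leave open what number any of them would give in this assay, and so whether going from (oxan-4-yl)oxy to hydroxy changes it at all.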